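The source may hold more compounds than are shown below. What is called first, only, known or untested is meant among the compounds shown, and "the series" means these compounds.

Measured so far in an assay (Equus caballus) for inhibition of Thromboxane-A synthase (Homo sapiens), using microsomes; a higher number here means a weaker inhibitor, a lower number a stronger inhibitor:
compound 1, `O=C(O)CCCC/C=C(\c1cccnc1)c1cccc(Br)c1`; compound 1 gives 180 nM
compound 2, `O=C(O)CCCC/C=C(\c1cccnc1)c1ccsc1`; compound 2 gives 31 nM
compound 3, `C/C(=C/CCCCC(=O)O)c1cccnc1`; compound 3 gives 71 nM

Compound 3 stands second highest of the three numbers in this assay. Its nearest neighbour is compound 2, with a 2.3-fold higher number from compound 2 to compound 3 (0.36 log units; beyond the scatter); the furthest is compound 1, with a 2.5-fold lower number from compound 1 to compound 3 (0.40 log units; beyond the scatter). Both steps are beyond the scatter but modest.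

Compound 4 is `Cc1ccc(/C(=C/CCCCC(=O)O)c2cccnc2)cc1`. Relative to compound 3 the change is: 4-methylphenyl in place of methyl on a double-bonded chain carbon bound to an aromatic carbon and a double-bonded chain carbon. Within the data shown here, two measured steps touch the same position. Replacing an aromatic group by methyl gave a 2.5-fold lower number from compound 1 to compound 3 (0.40 log units; beyond the scatter) in one case and a 2.3-fold higher number from compound 2 to compound 3 (0.36 log units; beyond the scatter) in the other, so the two aromatic groups already seen at this position fall on opposite sides of methyl. Among the measured compounds shown here, the group entering in compound 4 is a six-membered aromatic ring of carbon only, which so far resembles the substituent of compound 1 rather than that of compound 2. On that basis compound 4 is expected to give a somewhat higher number in this assay than compound 3, a step of about a 1.7-fold higher number from compound 3 to compound 4 (0.23 log units; within the scatter), with real uncertainty about whether it clears the scatter. Compound 4 is estimated at 120 nM, within a range of 45 nM to 320 nM.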

Compound 4, half-maximal inhibitory concentration: 85 nM
Estimate against measurement, compound 4: 1.4-fold (0.15 log units) above; low and high end bracket the measured number.
By their numbers in this assay, from the lowest: compound 2; then compounds 3 and 4 (each within the scatter of the next); then compound 1.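

In this assay, the 4-methylphenyl group at this position cannot be told apart from methyl, giving a 1.2-fold higher number from compound 3 to compound 4 (0.08 log units; within the scatter) despite bringing in 7 heavy atoms and a six-membered aromatic ring of carbon only. The aromatic groups do separate from one another, with a 2.7-fold higher number from compound 2 to compound 4 (0.44 log units; beyond the scatter) against thiophen-3-yl and a 2.1-fold lower number from compound 1 to compound 4 (0.33 log units; beyond the scatter) against 3-bromophenyl, so compounds 1 and 4 show that a six-membered aromatic ring of carbon only does not by itself fix the number at this position. No measurement on hand accounts for these differences.

The gap between 4-methylphenyl and 3-bromophenyl comes from two groups that differ in both substituent and its place on the ring, so the contribution of each stays unresolved. An unsubstituted phenyl group would give a common reference for both, and an ethyl group would show whether a small chain at this position also stays within the scatter of methyl.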